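Second Chloro on the Core of Compound 3

The source may report more compounds than this note shows. Statements on the series, on what has been measured and on what is new or still open speak of the compounds shown alone.

Compound 1 `CCCCC(CCO)n1cnc2c(Cl)ncnc21`: > 50000 nM
Compound 2 `CCCCC(CCO)n1cnc2cncnc21`: > 50000 nM
Compound 3 `CCCCCCCCC(CCO)n1cnc2c(Cl)ncnc21`: 1370 nM

In a functional assay on SW480 cells (Homo sapiens) for antiproliferative activity, read by MTT assay, with a stated time of 48 h (on this read-out higher numbers stand for weaker inhibition and lower numbers for stronger inhibition), compound 1 sits at the limit of > 50000 nM in this assay, at which 2 of the 3 values shown sit, which is a limit and not a number. Compound 2 likewise sits at that limit. Compound 3 gives the only number shown. The change from compound 2 to compound 1 is chloro in place of hydrogen on an aromatic carbon and gives a step that the two limits leave unreadable from compound 2 to compound 1. The change from compound 1 to compound 3 gives an at least 36-fold lower number from compound 1 to compound 3 (1.56 log units; beyond the scatter). The difference between the cores of compound 2 and compound 3 is not broken down here.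

Compound 4 `CCCCCCCCC(CCO)n1cnc2c(Cl)nc(Cl)nc21` is not yet measured. It differs from compound 3 by chloro in place of hydrogen on an aromatic carbon, the same kind of change as from compound 2 to compound 1, though here between two ring nitrogen atoms and meta to a chloro group rather than next to the ring nitrogen. Since the earlier step is unreadable, compound 4 is expected to stay near compound 3, an estimated 1.1-fold lower number from compound 3 to compound 4 (0.06 log units; within the scatter), giving 1200 nM.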

Compound 4, half-maximal inhibitory concentration: 24000 nM
For compound 4 the middle estimate is 20-fold (1.30 log units) below the measured one, outside the stated range (above it).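

In this assay, chloro in place of hydrogen on an aromatic carbon, here between two ring nitrogen atoms, gives an 18-fold higher number from compound 3 to compound 4 (1.24 log units; beyond the scatter). The same kind of change on the core of compound 2 cannot be read, since compound 2 and compound 1 both stand at a limit and not a number: the limit of > 50000 nM in this assay, at which 2 of the 4 values shown sit. This leaves one readable step for the change, on one core and at one place, and it does not show whether a step of this size would carry over to another core.

As far as these compounds go, whether an amine on that same carbon would stay near compound 3 or move as far as compound 4 remains open. So does how a longer chain than that of compound 3 would change the number.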